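Leaving the Thiophene Behind

A few compounds are considered here, and "the series" means these few. Any claim that something is new, unique, unknown or untested is made for them only; others in the source may bear on it.

In a toxicity assay on MT4 cells (Homo sapiens) for cytotoxicity, read by MTT assay, with a stated time of 5 days (a higher number here means that more compound is tolerated, a lower number that less compound is tolerated), compound 1 `Cc1cc(-c2ccnc3ccccc23)cc(C)c1Nc1ccnc(Nc2ccc(C#N)cc2)n1` gives 3500 nM and compound 2 `Cc1cc(-c2ccc3cc[nH]c3c2)cc(C)c1Nc1ccnc(Nc2ccc(C#N)cc2)n1` gives 5800 nM, a gap of a 1.7-fold higher number from compound 1 to compound 2 (0.22 log units; within the scatter). Compound 3 `Cc1csc(-c2cc(C)c(Nc3ccnc(Nc4ccc(C#N)cc4)n3)c(C)c2)c1` gives 34000 nM, the highest of the three numbers. Bringing in 4-methylthiophen-2-yl produced a 9.7-fold higher number from compound 1 to compound 3 (0.99 log units; beyond the scatter) and also a 5.9-fold higher number from compound 2 to compound 3 (0.77 log units; beyond the scatter). In compound 4 `Cc1cc(-c2ccnc(C(F)(F)F)c2)cc(C)c1Nc1ccnc(Nc2ccc(C#N)cc2)n1`, 2-(trifluoromethyl)pyridin-4-yl takes the place of 4-methylthiophen-2-yl on an aromatic carbon (2-(trifluoromethyl)pyridin-4-yl in place of 4-methylthiophen-2-yl on an aromatic carbon). Among the measured compounds shown here, no measured compound carries this new group, so those two modest steps offer only a rough guide. Removing the group that raised the number suggests a modest fall in this assay. The expected change is a 2.8-fold lower number from compound 3 to compound 4 (0.45 log units; beyond the scatter). For compound 4 the estimate is 12000 nM, with an expected range of 3500 nM to 40000 nM.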

Compound 4, half-maximal cytotoxic concentration: 6100 nM
The estimate for compound 4 lay 2.0-fold (0.29 log units) above the measured number; the range from low to high includes it.
By their numbers in this assay, from the lowest: compounds 1, 2 and 4 (each within the scatter of the next); then compound 3.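

Swapping the thiophene for the pyridine gives a 5.6-fold lower number from compound 3 to compound 4 (0.75 log units; beyond the scatter) in this assay and so shows that the high number at this position does not carry over to 2-(trifluoromethyl)pyridin-4-yl. Among the compounds shown here, compound 4 instead falls in with the two other compounds, with a 1.1-fold higher number from compound 2 to compound 4 (0.02 log units; within the scatter) and a 1.7-fold higher number from compound 1 to compound 4 (0.24 log units; within the scatter), leaving 4-methylthiophen-2-yl as the only group here that stands apart. No measurement shown gives a reason for this. As far as these compounds go, it remains open whether the high number comes from the thiophene ring or from its methyl group, and whether an amine or a carboxylic acid at this position would reach it.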